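Swapping a Pyrrolidinyl Group for an Imidazolyl Group

The source may hold more compounds than are shown below. What is called first, only, known or untested is meant among the compounds shown, and "the series" means these compounds.

Compound 1 `COc1ccc(C(=O)/C=C/c2ccc(-c3ccccc3)cc2)c2c1C=CC(C)(C)O2`: > 10000 nM
Compound 2 `COc1ccc(C(=O)/C=C/c2ccc(N3CCCC3)cc2)c2c1C=CC(C)(C)O2`: 8360 nM

In a functional assay on HT-29 cells (Homo sapiens) for antiproliferative activity, read by MTT assay, with a stated time of 24 h (a lower number here means a stronger inhibitor, a higher number a weaker inhibitor), compound 1 reaches only the assay limit (the limit of > 10000 nM in this assay, at which 1 of the 2 values shown sits). In this assay, going by the values given here, compound 2 gives 8360 nM, the sole number among the values shown. The step of an at least 1.1-fold lower number from compound 1 to compound 2 (0.07 log units; that floor lies within the scatter) stays within the scatter. Compound 3 `COc1ccc(C(=O)/C=C/c2ccc(-n3ccnc3)cc2)c2c1C=CC(C)(C)O2` differs from compound 2 by 1H-imidazol-1-yl in place of pyrrolidin-1-yl on an aromatic carbon. No measured step bears directly on this change; the one step shown moved little. Compound 3 is therefore expected near 8000 nM, within 2500 nM to 25000 nM. The step estimated for it is a 1.0-fold lower number from compound 2 to compound 3 (0.02 log units; within the scatter).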

Compound 3, half-maximal inhibitory concentration: > 6600 nM
Compound 3 ended at the assay's limit (the forecaster's own chance of this, stated with the estimate: 40%); the middle value does not contradict the limit.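

Compound 3 gives a limit of the assay rather than a number, so neither the step from compound 2 to compound 3 nor the step from compound 1 to compound 3 can be read: the limit of > 6600 nM in this assay, at which 1 of the 3 values shown sits.

The compounds shown leave open how 1H-imidazol-1-yl compares with pyrrolidin-1-yl in antiproliferative activity.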